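A few compounds are considered here, and "the series" means these few. Any claim that something is new, unique, unknown or untested is made for them only; others in the source may bear on it.

Measured so far in a functional assay on NCI-H460 cells (Homo sapiens) for antiproliferative activity, with a stated time of 72 h; a lower number here means a stronger inhibitor, a higher number a weaker inhibitor:
compound 1 `C=CC[C@H]1C[C@]2([C@H](C)Cc3ccc(OC)c(OC)c3)OCOC2=CC1=O`: 320 nM
compound 2 `C=CC[C@H]1C[C@]2(CCc3ccc(OC)c(OC)c3)OCOC2=CC1=O`: 3200 nM
compound 3 `C=CC[C@H]1C[C@]2([C@@H](C)Cc3ccc(OC)c(C)c3)OCOC2=CC1=O`: 630 nM

Compound 3 gives the second highest of the three numbers in this assay. Its nearest neighbour is compound 1, from which it is separated by a gap within the scatter, so the two cannot be ordered; compound 2 stands further off, beyond the scatter, with the higher number. Going by the values given here, the one single-point step measured, a 10-fold higher number from compound 1 to compound 2 (1.00 log units; beyond the scatter), concerns the saturated chain carbon and not the aromatic ring.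

Compound 4 `C=CC[C@H]1C[C@]2([C@@H](C)Cc3ccc(OC)c(O)c3)OCOC2=CC1=O` is the next member. It differs from compound 3 by hydroxy in place of methyl on an aromatic carbon, ortho to a methoxy group and meta to a large group. Among the compounds with values here, no measured step touches this position. Within the data shown here, compounds 1 and 3, which carry different groups there (methoxy against methyl), give numbers within the scatter of each other, and that is the only guide available. The step of a 10-fold higher number from compound 1 to compound 2 (1.00 log units; beyond the scatter) lies at another place and does not bear on the change. The expected step of a 1.1-fold higher number from compound 3 to compound 4 (0.05 log units; within the scatter) is therefore small, none beyond the scatter, with the direction open. Compound 4 is estimated at 700 nM, range 250 nM to 2000 nM.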

Compound 4, half-maximal inhibitory concentration: 80 nM
Compound 4: the middle estimate sits 8.8-fold (0.94 log units) above what was measured, and the stated range ends above it.
By their numbers in this assay, from the lowest: compound 4; then compounds 1 and 3 (each within the scatter of the next); then compound 2.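

Working notes on the series: in this assay, the aromatic carbon ortho to a methoxy group and meta to a large group proves sensitive to a one-atom exchange, since hydroxy in place of methyl gives a 7.9-fold lower number from compound 3 to compound 4 (0.90 log units; beyond the scatter). Going by these compounds alone, this is the first matched reading at this position, and it places a second step beyond the scatter, alongside a 10-fold higher number from compound 1 to compound 2 (1.00 log units; beyond the scatter) at the saturated chain carbon. The exchange adds one hydrogen-bond donor and one hydrogen-bond acceptor by count, but no measurement on hand accounts for the step.

With only methyl and hydroxy forming a matched pair at this position, the compounds shown do not settle whether the lower number is specific to hydroxy, and an amine, a carboxylic acid or a hydroxymethyl group there would test how narrow the requirement is. Also open is whether the step carries over to the opposite configuration at the methyl-bearing chain carbon, or to the chain without that methyl, as neither has a hydroxy counterpart among these compounds.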